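The compounds below may be only part of what the source reports. "The series", "measured", "known", "first", "only" and "open" are said of these compounds alone.

Working notes on a short thiosemicarbazone series.

Compound 1 `N/C(=N\NC(=S)N1CCCCCC1)c1ccccn1` and compound 3 `Cc1ccnc(/C(N)=N/NC(=S)N2CCCCCC2)c1` share one core, compound 2 `Cc1ccnc(/C(N)=N/NC(=S)N2CCN(c3ccccn3)CC2)c1` carries a second one, and compound 4 `N/C(=N\NC(=S)N1CCN(c2ccccn2)CC1)c1ccccn1` is not yet measured. In a functional assay on A-375 cells (Homo sapiens) for cytotoxicity, read by MTT assay, with a stated time of 72 h (on this read-out higher numbers stand for weaker inhibition and lower numbers for stronger inhibition), compound 1 gives 740 nM. In this assay compound 3 gives 800 nM, and in this assay compound 2 gives 780 nM. All three numbers sit close together.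

Among the measured compounds shown here, the one counted step among the measured compounds runs from compound 3 to compound 1, where hydrogen in place of methyl on an aromatic carbon brings a 1.1-fold lower number from compound 3 to compound 1 (0.03 log units; within the scatter). How the core of compound 2 differs from the core of compound 3 is not broken down here; the two compounds differ in more than one place, and their values alone show no gap beyond the usual scatter.

Compound 4 arises from compound 2 by the same change, (hydrogen in place of methyl on an aromatic carbon); the place is described in the same words for both pairs, so it is the same change on a different core. For the measured compounds named here, only one earlier instance exists, and a single pair cannot establish a pattern. On that basis the step from compound 2 to compound 4 is expected to be a 1.1-fold lower number from compound 2 to compound 4 (0.03 log units; within the scatter), a near-flat move resting on compound 3 to compound 1 having given a 1.1-fold lower number from compound 3 to compound 1 (0.03 log units; within the scatter). Compound 4 is therefore estimated at 720 nM in this assay, with a plausible range from 400 nM to 1400 nM.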

Compound 4, half-maximal inhibitory concentration: 700 nM
Compound 4: middle estimate off by 1.0-fold (0.01 log units), on the high side; the range from low to high includes it.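

On the second core, the change from 4-methylpyridin-2-yl to pyridin-2-yl gives a 1.1-fold lower number from compound 2 to compound 4 (0.05 log units; within the scatter) in this assay. Set beside the earlier step, the same change reads alike on the two cores: the same change on two cores in this assay, a 1.1-fold lower number (0.03 log units; within the scatter) from compound 3 to compound 1 and a 1.1-fold lower number (0.05 log units; within the scatter) from compound 2 to compound 4, 1.0-fold (0.01 log units) apart, within the scatter of two such steps. This shows that swapping methyl for hydrogen at this place, opposite the ring nitrogen, is a near-flat move on both cores in this series, but it does not show a rule for other cores, and since neither step lies beyond the scatter, these two pairs cannot show whether a larger effect of this change would carry from one core to another.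

The compounds shown hold only methyl or hydrogen at this place, so it remains open whether a methoxy group, a chlorine atom, a primary amine or a longer alkyl chain there would move the number beyond the scatter. Also open, going by these compounds, is whether the flat result holds on a core other than these two, or on cells other than those used in this assay.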